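Hydroxamate chain length on the shared core

The compounds below may be only part of what the source reports. "The series", "measured", "known", "first", "only" and "open" are said of these compounds alone.

Measured in a functional assay on MCF7 cells (Homo sapiens) for inhibition, read by MTT assay, with a stated time of 72 h; a higher number here means a weaker inhibitor, a lower number a stronger inhibitor:
compound 1 `Nc1nc2cc(-c3nn(CCCCCC(=O)NO)c4ncnc(N)c34)ccc2o1` gives 12400 nM
compound 2 `Nc1ncnc2c1c(-c1cnc3[nH]ccc3c1)nn2CCCCCCC(=O)NO` gives 19800 nM
compound 3 `Nc1nc2cc(-c3nn(CCC(=O)NO)c4ncnc(N)c34)ccc2o1` gives > 100000 nM, a limit of the assay rather than a number.

Among the measured compounds shown here, compound 3 thus stands only at a limit in this assay; it is the single value sitting at the limit of > 100000 nM in this assay, at which 1 of the 3 values shown sits. Compound 1 and compound 2 both give numbers, and those two lie within the usual scatter of each other.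

The change to compound 4 `Nc1nc2cc(-c3nn(CCCCCCC(=O)NO)c4ncnc(N)c34)ccc2o1` is 4-(hydroxycarbamoyl)butyl in place of hydroxycarbamoyl on a saturated chain carbon, two bonds along the chain from an aromatic nitrogen. For the measured compounds named here, the one measured step that bears on it runs the opposite way: an at least 8.0-fold higher number from compound 1 to compound 3 (0.90 log units; beyond the scatter), so removing the chain cost at least that much. Compound 4 carries 4-(hydroxycarbamoyl)butyl where compound 1 carries 3-(hydroxycarbamoyl)propyl, and restoring a chain is expected to recover most of that loss, giving a markedly lower number in this assay. Compound 2, which carries a chain of the same length on a different core, gives 19800 nM in this assay, a number of the same order as compound 1.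

For compound 4 the expected step is an at least 8.3-fold lower number from compound 3 to compound 4 (0.92 log units; beyond the scatter). Compound 4 is therefore estimated at 12000 nM, with a range from 4000 nM to 40000 nM.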

Compound 4, half-maximal inhibitory concentration: 11900 nM
The estimate for compound 4 lay 1.0-fold (0.00 log units) above the measured number, and the stated range covers the measured number.
By their numbers in this assay, from the lowest: compounds 4, 1 and 2 (each within the scatter of the next). At a limit, above all of these: compound 3.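

In this assay, 4-(hydroxycarbamoyl)butyl in place of hydroxycarbamoyl, on a saturated chain carbon, two bonds along the chain from an aromatic nitrogen, gives an at least 8.4-fold lower number from compound 3 to compound 4 (0.92 log units; beyond the scatter); this step is read from a limit of the assay on compound 3, so its size is only a minimum: the limit of > 100000 nM in this assay, at which 1 of the 4 values shown sits.

The earlier compounds shown here left open whether one more chain carbon on the shared core would change the number, and a 1.0-fold lower number from compound 1 to compound 4 (0.02 log units; within the scatter) shows no readable change between 3-(hydroxycarbamoyl)propyl and 4-(hydroxycarbamoyl)butyl. With the chain held the same, the change of aromatic group gives a 1.7-fold lower number from compound 2 to compound 4 (0.22 log units; within the scatter), so these two aromatic groups cannot be told apart in this assay.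

The compounds shown leave open where between hydroxycarbamoyl and 3-(hydroxycarbamoyl)propyl the number starts to fall, and whether a longer chain such as 6-(hydroxycarbamoyl)hexyl keeps it at the same level. They also leave open whether the step depends on the hydroxycarbamoyl end itself, which a carboxylic acid at the end of the same chain would test.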